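Sulfonyl chain extension from compound 2 to compound 4

A few compounds are considered here, and "the series" means these few. Any claim that something is new, unique, unknown or untested is made for them only; others in the source may bear on it.

Values in a functional assay on Huh-7 cells (Homo sapiens) for cytotoxicity, read by MTT assay, with a stated time of 72 h (a higher number here means that more compound is tolerated, a lower number that less compound is tolerated), each one a limit:
- compound 1 `CCS(=O)(=O)N1CCC2(CC1)OOC1(CCCC1)OO2` gives > 100 ug/mL as a limit
- compound 2 `CCS(=O)(=O)N1CCC2(CC1)OOC1(CCCCC1)OO2` gives > 100 ug/mL as a limit
- compound 3 `CCCS(=O)(=O)N1CCC2(CC1)OOC1(CCCC1)OO2` gives > 100 ug/mL as a limit

Compound 2 stands only at its limit of > 100 ug/mL with no number. The change to compound 4 `CCCCS(=O)(=O)N1CCC2(CC1)OOC1(CCCCC1)OO2` is ethyl in place of hydrogen on a saturated chain carbon, two bonds along the chain from a sulfonyl sulfur, which takes ethylsulfonyl to butylsulfonyl. Going by the values given here, the one measured step at this place is a step that the two limits leave unreadable from compound 1 to compound 3, where methyl enters. The wider picture is the limit of > 100 ug/mL in this assay, at which 3 of the 3 values shown sit, so no step beyond the scatter is expected in this assay and the estimated change is a number no higher from compound 2 to compound 4 (the limit leaves the size open) overall. Compound 4 is expected at about 100 ug/mL as the estimate. Compound 4 has an expected range of 50 ug/mL to 200 ug/mL and will most likely read as a limit again.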

Compound 4, half-maximal cytotoxic concentration: > 100 ug/mL
Compound 4: a limit, no number (the forecaster's own chance of this, stated with the estimate: 85%); the middle value lies on the limit itself.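

In this assay, going by these compounds alone, compound 2 and compound 4 both stand as limits, so no step between them can be read: the limit of > 100 ug/mL in this assay, at which 4 of the 4 values shown sit. The compounds shown leave open at what concentration any of them turns cytotoxic, and whether sulfonyl chain length then matters.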